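The source may report more compounds than this note shows. Statements on the series, on what has been measured and on what is new or still open speak of the compounds shown alone.

Measured so far in an in vitro functional assay on cells for agonist activity at Bombesin receptor subtype-3 (Homo sapiens), read by luminescence and calcium flux; on this read-out lower numbers stand for an effect already at smaller amounts and higher numbers for an effect only at larger amounts of compound:
compound 1 `O=C(O)c1ccccc1-c1ccc(CCc2ncc(Cc3cccc(Cl)c3)[nH]2)cc1` — compound 1 gives 825 nM
compound 2 `O=C(O)c1ccccc1-c1ccc(CCc2ncc(CC3CCC3)[nH]2)cc1` — compound 2 gives 588 nM
compound 3 `O=C(O)c1ccccc1-c1ccc(CCc2ncc(CC3CCCCCC3)[nH]2)cc1` — compound 3 gives 88 nM

Compound 3 has the lowest number of the three; both steps reaching it, a 9.4-fold lower number from compound 1 to compound 3 (0.97 log units; beyond the scatter) and a 6.7-fold lower number from compound 2 to compound 3 (0.82 log units; beyond the scatter), lie beyond the scatter, whereas a 1.4-fold lower number from compound 1 to compound 2 (0.15 log units; within the scatter) does not. Compound 4 `Cc1cccc(Cc2cnc(CCc3ccc(-c4ccccc4C(=O)O)cc3)[nH]2)c1` is not yet measured. It differs from compound 3 by 3-methylphenyl in place of cycloheptyl on a saturated chain carbon bound to an aromatic carbon. The measured step that bears most directly on this replaced a six-membered aromatic ring of carbon only by cycloheptyl at the same saturated chain carbon: a 9.4-fold lower number from compound 1 to compound 3 (0.97 log units; beyond the scatter). The change to compound 4 runs the other way, from the seven-membered non-aromatic ring back to a six-membered aromatic ring, so a rise of comparable size is expected. The step of a 6.7-fold lower number from compound 2 to compound 3 (0.82 log units; beyond the scatter) adds that the smaller saturated ring also sits well above compound 3. The step in this assay is therefore expected to be a 6.8-fold higher number from compound 3 to compound 4 (0.83 log units; beyond the scatter). Compound 4 is estimated at 600 nM in this assay, with a range from 200 nM to 2000 nM. Going by the values given here, the range is kept wide, as no measured pair compares 3-methylphenyl with 3-chlorophenyl.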

Compound 4, half-maximal effective concentration: 4310 nM
The estimate for compound 4 lay 7.2-fold (0.86 log units) below the measured number; measured number outside the range, above it.
By their numbers in this assay, from the lowest: compound 3; then compounds 2 and 1 (each within the scatter of the next); then compound 4.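

In this assay, going by these compounds alone, the swap of cycloheptyl for 3-methylphenyl on the saturated chain carbon bound to an aromatic carbon gives a 49-fold higher number from compound 3 to compound 4 (1.69 log units; beyond the scatter), the largest step so far, and it comes with no change in the count of heavy atoms or hydrogen-bond donors and acceptors in the group. The aromatic ring alone does not set the number at this place, since methyl in place of chloro on an aromatic carbon gives a 5.2-fold higher number from compound 1 to compound 4 (0.72 log units; beyond the scatter), so a single substituent on that ring shifts the result beyond the scatter. The earlier match between the 3-chlorophenyl and cyclobutyl groups therefore does not extend to every aromatic group, as 3-methylphenyl in place of cyclobutyl gives a 7.3-fold higher number from compound 2 to compound 4 (0.87 log units; beyond the scatter).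

No measurement at hand gives a reason for these steps. Still open, from the compounds shown here alone, are how the number runs through cyclopentyl and cyclohexyl between the cyclobutyl and cycloheptyl groups, and where an unsubstituted phenyl ring or a 3-methoxyphenyl or 3-fluorophenyl group would fall relative to the 3-chlorophenyl and 3-methylphenyl groups.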